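Lipophilicity notes: replacing the thienylsulfanyl arm with a carbamate

The compounds below may be only part of what the source reports. "The series", "measured", "known", "first", "only" and "open" are said of these compounds alone.

Measured so far:
compound 1 `O=C1CSC(=O)N1C[C@H]1CN(c2ccc(-n3cc(-c4ccccn4)cn3)c(F)c2)C(=O)O1` — 2.18
compound 2 `O=C1O[C@@H](CSc2cccs2)CN1c1ccc(-n2cc(-c3ccccn3)cn2)c(F)c1` — 4.29

Compound 2 stands highest of the two numbers in a physicochemical assay for lipophilicity, read by HPLC, measured as octanol-water partition; on this read-out higher numbers stand for higher lipophilicity and lower numbers for lower lipophilicity; its nearest neighbour is compound 1, which lies lower by the step of a number 2.11 log units higher from compound 1 to compound 2 (beyond the scatter). Compound 3 `COC(=O)NC[C@H]1CN(c2ccc(-n3cc(-c4ccccn4)cn3)c(F)c2)C(=O)O1` is the next member, unmeasured. Relative to compound 2 the change is (methoxycarbonyl)amino in place of (thiophen-2-yl)sulfanyl on a saturated chain carbon bound to a saturated ring carbon. Among the measured compounds shown here, only one measured step bears on this site: a number 2.11 log units higher from compound 1 to compound 2 (beyond the scatter), where the thienylsulfanyl group entered at the same carbon in place of 2,4-dioxo-1,3-thiazolidin-3-yl. Compound 3 takes that group away again and puts (methoxycarbonyl)amino there; since the earlier step was large and upward, a large step downward is expected here, roughly of the same size, with (methoxycarbonyl)amino treated as closer to the group of compound 1 than to that of compound 2. The expected step is a number 2.19 log units lower from compound 2 to compound 3 (beyond the scatter). For compound 3 the estimate in this assay is 2.1, within 1.5 to 2.7.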

Compound 3, partition coefficient: 2.03
Estimate against measurement, compound 3: 0.07 log units above, and the stated range covers the measured number.
By their numbers in this assay, from the lowest: compounds 3 and 1 (each within the scatter of the next); then compound 2.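

In this assay, (methoxycarbonyl)amino on this saturated chain carbon gives a number 2.26 log units lower from compound 2 to compound 3 (beyond the scatter), so a group with no ring also reads far from (thiophen-2-yl)sulfanyl at this place. The open-chain (methoxycarbonyl)amino and the ring-bearing 2,4-dioxo-1,3-thiazolidin-3-yl cannot be told apart here, with a number 0.15 log units lower from compound 1 to compound 3 (within the scatter), and among these three compounds only compound 2 stands apart. No supporting data are available to account for these numbers.

On these data alone, whether the high number of compound 2 goes with the thiophen-2-yl ring, the sulfur link or the two together stays open, and methylsulfanyl or thiophen-2-ylmethyl at the same carbon would separate them. Also open, as far as these compounds go, is where an amine or a carboxylic acid at this place would fall relative to compound 1 and compound 3.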